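Swapping the Aryl on the Amine of a Shared Core

The source may hold more compounds than are shown below. What is called first, only, known or untested is meant among the compounds shown, and "the series" means these compounds.

Of the compounds shown here, three sharing one core have been measured in a functional assay on PC-3 cells (Homo sapiens) for inhibition, read by MTT assay, with a stated time of 72 h; a higher number here means a weaker inhibitor, a lower number a stronger inhibitor. Compound 1 `O=C(CSc1nc(Nc2ccccc2)c2ccccc2n1)Nc1ccc([N+](=O)[O-])cc1` gives 25000 nM, compound 2 `CCc1ccc(NC(=O)CSc2nc(Nc3ccccc3)c3ccccc3n2)cc1` gives 17900 nM, and compound 3 `C=CC(=O)Nc1cccc(NC(=O)CSc2nc(Nc3ccccc3Br)c3ccccc3n2)c1` gives 17100 nM. The step of a 1.4-fold lower number from compound 1 to compound 2 (0.15 log units; within the scatter) is within the scatter, and compound 3 stands with the smallest of the three numbers while remaining within the scatter of both compound 1 and compound 2, so none of the three can be separated from the others.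

Compound 4 `C=CC(=O)Nc1cccc(NC(=O)CSc2nc(Nc3ccc(Cl)c(Cl)c3)c3ccccc3n2)c1` differs from compound 3 in one place: 3,4-dichlorophenyl in place of 2-bromophenyl on a nitrogen on an aromatic ring. Among the compounds with values here, no measured step touches this part of the molecule; the only step on record, from compound 1 to compound 2, concerns the other aromatic ring and was itself within the scatter. With nothing pointing in either direction, the expectation is a step of a 1.0-fold lower number from compound 3 to compound 4 (0.00 log units; within the scatter) that stays within the scatter. Compound 4 is therefore estimated at 17000 nM in this assay, with a range from 6000 nM to 48000 nM.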

Compound 4, half-maximal inhibitory concentration: 27600 nM
Compound 4: middle estimate off by 1.6-fold (0.21 log units), on the low side, within the range that was stated.
By their numbers in this assay, from the lowest: compounds 3, 2, 1 and 4 (each within the scatter of the next).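

Within the data shown here, this is the first measured step at the aryl group on this nitrogen, since the earlier step concerned the other aromatic ring. In this assay, putting 3,4-dichlorophenyl in place of 2-bromophenyl gives a 1.6-fold higher number from compound 3 to compound 4 (0.21 log units; within the scatter). The position therefore takes this exchange of one halogen-bearing phenyl for another without a change that can be told apart from ordinary measurement variation, and nothing measured here offers an explanation for the size of the step.

This single step swaps the kind of halogen, their number and where they sit all at once, so it cannot separate these changes. It also leaves open whether a phenyl carrying a carboxylic acid or an amine, or a simple alkyl chain in place of the phenyl, would move the number beyond the scatter.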